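Replacing the Chloromethylphenyl Group with a Cyanopyridine Ring

A few compounds are considered here, and "the series" means these few. Any claim that something is new, unique, unknown or untested is made for them only; others in the source may bear on it.

Of the compounds shown here, three sharing one core have been measured in a functional assay on BJAB cells (Homo sapiens) for antiproliferative activity, with a stated time of 4 days; a lower number here means that less compound is needed, a higher number that more compound is needed for the effect. Compound 1 `Cc1nn(-c2nc(-c3ccc(Cl)c(Cl)c3)c(SC(C)C)s2)c(C(=O)O)c1-c1cncnc1` gives 22000 nM, compound 2 `Cc1nn(-c2nc(-c3ccc(Cl)c(Cl)c3)c(SC(C)C)s2)c(C(=O)O)c1-c1cnn(C)c1` gives 6800 nM, and compound 3 `Cc1cc(Cl)cc(-c2c(C)nn(-c3nc(-c4ccc(Cl)c(Cl)c4)c(SC(C)C)s3)c2C(=O)O)c1` gives 663 nM. Compound 3 thus stands lowest of the three, so the least of it is needed for the effect; compound 2 is the nearest to it and compound 1 the furthest. The three differ only in the group on an aromatic carbon of the five-membered aromatic ring with 2 nitrogen: a pyrimidin-5-yl, a 1-methyl-1H-pyrazol-4-yl and a 3-chloro-5-methylphenyl.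

Compound 4 `Cc1nn(-c2nc(-c3ccc(Cl)c(Cl)c3)c(SC(C)C)s2)c(C(=O)O)c1-c1cncc(C#N)c1` changes that group once more: 5-cyanopyridin-3-yl in place of 3-chloro-5-methylphenyl on an aromatic carbon. The incoming group is a six-membered aromatic ring with 1 hetero atom carrying a nitrile, whereas compound 3 carries a ring of carbon only.

For the measured compounds named here, two measured steps bear on this. Replacing a pyrimidin-5-yl gave a 33-fold lower number from compound 1 to compound 3 (1.52 log units; beyond the scatter), and replacing a 1-methyl-1H-pyrazol-4-yl gave a 10-fold lower number from compound 2 to compound 3 (1.01 log units; beyond the scatter). In both, the ring of carbon only gave the lower number. Moving back to a ring with a hetero atom and hydrogen-bond acceptors is therefore expected to raise the number, though no compound with exactly this ring has been measured. The estimated step is a 7.5-fold higher number from compound 3 to compound 4 (0.88 log units; beyond the scatter). Compound 4 is expected to give about 5000 nM, with a likely range from 1500 nM to 20000 nM.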

Compound 4, half-maximal effective concentration: 20000 nM
The estimate for compound 4 lay 4.0-fold (0.60 log units) below the measured number; measured number inside the range.
By their numbers in this assay, from the lowest: compound 3; then compound 2; then compounds 4 and 1 (each within the scatter of the next).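

In this assay, swapping the 3-chloro-5-methylphenyl group for 5-cyanopyridin-3-yl gives a 30-fold higher number from compound 3 to compound 4 (1.48 log units; beyond the scatter), which removes almost all of the advantage compound 3 held over the other compounds. All three rings with hetero atoms now give higher numbers than the ring of carbon only in compound 3, with no exception among these four compounds, and the pattern extends to a ring that carries a nitrile. Among those three rings, the 1-methyl-1H-pyrazol-4-yl group keeps the lowest number, with a 2.9-fold higher number from compound 2 to compound 4 (0.47 log units; beyond the scatter), whereas the 5-cyanopyridin-3-yl and pyrimidin-5-yl groups cannot be told apart, with a 1.1-fold lower number from compound 1 to compound 4 (0.04 log units; within the scatter).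

No measurement shown here accounts for the gap between compound 3 and the compounds with hetero atoms in this ring. As far as these compounds go, it also stays open whether the ring nitrogen, the nitrile or the missing chlorine and methyl group matters most: a phenyl ring carrying a nitrile, or a pyridine ring carrying a chlorine and a methyl group, would help to separate these changes.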